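Changing the aryl on the triazole nitrogen: compound 3 to compound 4

The source may hold more compounds than are shown below. What is called first, only, known or untested is meant among the compounds shown, and "the series" means these compounds.

Compound 1 `COc1ccccc1-n1nncc1CN1C(=O)C2(C(C#N)=C(N)Oc3c2c2nc4ccccc4nc2c2ccccc32)c2ccccc21` — in an ADME assay on L02 cells (Homo sapiens) for antiproliferative activity, read by MTT assay, with a stated time of 48 h (a lower number here means a stronger inhibitor, a higher number a weaker inhibitor), compound 1 gives > 50000 nM, which is a limit of the assay rather than a number.
Compound 2 `Cc1ccc(-n2nncc2CN2C(=O)C3(C(C#N)=C(N)Oc4c3c3nc5ccccc5nc3c3ccccc43)c3ccccc32)c(C)c1` — in this assay compound 2 gives > 50000 nM, also a limit rather than a number.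
Compound 3 `N#CC1=C(N)Oc2c(N)cc3nc4ccccc4nc3c2C12C(=O)N(Cc1cnnn1-c1cccc(C(F)(F)F)c1)c1ccccc12` — in this assay compound 3 gives 38100 nM.

Among the three measured compounds, compound 3 is the only one with an actual number; compounds 1 and 2 both sit at the limit of > 50000 nM in this assay, at which 2 of the 3 values shown sit. Among the compounds with values here, the single step between measured compounds, a step that the two limits leave unreadable from compound 1 to compound 2, also changes the aryl group on the aromatic nitrogen of the triazole. Both of its ends are limits, and its size cannot be read. It therefore offers no guide to how large a change of this kind can be.

Compound 4 `Cc1ccc(Cl)cc1-n1nncc1CN1C(=O)C2(C(C#N)=C(N)Oc3c(N)cc4nc5ccccc5nc4c32)c2ccccc21` differs from compound 3 in one place: 5-chloro-2-methylphenyl in place of 3-(trifluoromethyl)phenyl on an aromatic nitrogen. With no readable measured step bearing on this change, there is no basis to expect a shift beyond the usual scatter in either direction. Compound 4 is therefore expected to give about 40000 nM in this assay, estimated to fall between 15000 nM and 100000 nM. The expected step of a 1.0-fold higher number from compound 3 to compound 4 (0.02 log units; within the scatter) is estimated to lie within the scatter, with a fair chance that only a limit is reported.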

Compound 4, half-maximal inhibitory concentration: > 50000 nM
Compound 4: only a limit was reported; the forecaster's own chance of this, stated with the estimate: 40%; middle value at least 1.2-fold (0.09 log units) away from the limit.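

Within the data shown here, putting 5-chloro-2-methylphenyl in place of 3-(trifluoromethyl)phenyl on the aromatic nitrogen gives an at least 1.3-fold higher number from compound 3 to compound 4 (0.11 log units; that floor lies within the scatter), the first step at this position with a measured number at one end. Compound 4 reports only a limit, so this step is a floor: the true gap may be larger, but the floor itself does not show a change beyond the usual scatter. The limit now appears on the core of compound 3 as well, while compound 3 remains the one exception with a number in this assay, so the data show how often this ceiling is met but do not explain it: the limit of > 50000 nM in this assay, at which 3 of the 4 values shown sit.

Going by these compounds, how far compound 4 lies past its limit stays unknown, so the true size of this step remains open, and the unreadable step between compounds 1 and 2 cannot help to settle it. Also open, on these data alone, is whether an aryl group carrying an amine or a carboxylic acid, or a cyclohexyl ring in place of the aryl group, would give a readable number in this assay on either core.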